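Aryl ether in place of an alkyl ether

The source may report more compounds than this note shows. Statements on the series, on what has been measured and on what is new or still open speak of the compounds shown alone.

Within the data shown here, compound 1 `CCOC1=CC(=O)c2ccccc2C1=O` gives 16900 nM in a functional assay on KB cells (Homo sapiens) for cytotoxicity (a higher number here means a weaker inhibitor, a lower number a stronger inhibitor), the highest of the two numbers measured so far. Compound 2 `O=C(Oc1ccc2c(c1)C(=O)C=CC2=O)c1ccccc1` gives 12100 nM in this assay, which lies within the usual scatter of compound 1, so no order between the two can be claimed. Compound 3 `O=C1C=C(Oc2cccs2)C(=O)c2ccccc21` has not yet been measured in this assay. It differs from compound 1 by thiophen-2-yl in place of ethyl on an oxygen on an unsaturated carbon. Among the measured compounds shown here, no step between measured compounds is known, so the step of a 1.7-fold lower number from compound 1 to compound 3 (0.23 log units; within the scatter) is expected to be small, toward a lower number, and may not exceed the scatter. Compound 3 is expected to give 10000 nM, with a range from 3000 nM to 35000 nM.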

Compound 3, half-maximal inhibitory concentration: 41500 nM
Estimate against measurement, compound 3: 4.2-fold (0.62 log units) below, and the stated range ends below it.
By their numbers in this assay, from the lowest: compounds 2 and 1 (each within the scatter of the next); then compound 3.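

In this assay, thiophen-2-yl in place of ethyl on this oxygen gives a 2.5-fold higher number from compound 1 to compound 3 (0.39 log units; beyond the scatter) and so moves the number upward, showing that this position responds to the ether group. Among these compounds, this is the first step to lie beyond the scatter, though it is modest. No measurement at hand bears on the reason for this step.

Still open, from the compounds shown here alone, is whether a phenyl ether or a longer chain such as butyl on the same oxygen would read like compound 1 or compound 3. Also open, going by these compounds, is how an amine in place of the ether would read.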